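The source may report more compounds than this note shows. Statements on the series, on what has been measured and on what is new or still open speak of the compounds shown alone.

Compound 1, `COc1ccc2[nH]c(C(=O)N3CC(=O)N(Cc4ccccc4)[C@@H](CCc4ccccc4)C3)cc2c1`, gives > 30000 nM in an ADME assay on Vero cells (Chlorocebus sabaeus) for cytotoxicity, with a stated time of 7 days; a lower number here means that less compound is tolerated, a higher number that more compound is tolerated. This value is a limit of the assay.
Compound 2, `COc1ccc2[nH]c(C(=O)N3CC(=O)N(Cc4ccccc4)[C@@H](COC(C)(C)C)C3)cc2c1`, gives 78200 nM in this assay.
Compound 3, `COc1ccc2[nH]c(C(=O)N3CC(=O)N(Cc4ccccc4)[C@@H](Cc4ccccn4)C3)cc2c1`, gives > 30000 nM in this assay. This value is a limit of the assay, not a number.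

Compound 3 thus stands only at a limit, and the limit of > 30000 nM in this assay, at which 2 of the 3 values shown sit, shows that it shares this position with one other of the three values. Compound 4, `COc1ccc2[nH]c(C(=O)N3CC(=O)N(Cc4ccccc4)[C@@H](CN4CCN(c5ccccn5)CC4)C3)cc2c1`, differs from compound 3 in one place: 4-(pyridin-2-yl)piperazin-1-yl in place of pyridin-2-yl on a saturated chain carbon bound to a saturated ring carbon. The measured steps that lead to compound 3, a step that the two limits leave unreadable from compound 1 to compound 3 and a step that the limit leaves unreadable from compound 2 to compound 3, cannot be read in size, so they give no guide to the direction or size of the step in this assay. The step expected here, a step that the limit leaves unreadable from compound 3 to compound 4, is therefore taken as small. Compound 4 is estimated at 50000 nM, with a range from 20000 nM to 120000 nM.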

Compound 4, half-maximal cytotoxic concentration: > 30000 nM
Compound 4 gave a limit, no number; the forecaster's own chance of this, stated with the estimate: 60%; the middle value lies beyond the limit too.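

Compound 4 stands at a limit, not a number: the limit of > 30000 nM in this assay, at which 3 of the 4 values shown sit.

Within the data shown here, no step from compound 1, compound 2 or compound 3 to compound 4 can be read in size. Going by these compounds, what stays open is where the true values of compound 1, compound 3 and compound 4 lie, and whether these groups change cytotoxicity at all.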